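A few compounds are considered here, and "the series" means these few. Any claim that something is new, unique, unknown or untested is made for them only; others in the source may bear on it.

In a functional assay on L1210 cells (Mus musculus) for inhibition (on this read-out higher numbers stand for weaker inhibition and lower numbers for stronger inhibition), compound 1 (`C#CCN(Cc1ccc2nc(C)nc(O)c2c1)c1cccc(C)c1`) gives > 5000 nM as a limit of the assay. Compound 2 (`C#CCN(Cc1ccc2nc(C)nc(O)c2c1)c1cccc(C#C)c1`) gives > 2400 nM as a limit too, so its place on the scale is known only as a limit. Within the data shown here, compound 3 (`C#CCN(Cc1ccc2nc(C)nc(O)c2c1)c1ccc(Cl)cc1`) keeps the shared core and carries 4-chlorophenyl in place of 3-ethynylphenyl on an amine nitrogen as its one change from compound 2. Among the measured compounds shown here, the only measured step bearing on this is the exchange of methyl for ethynyl on an aromatic carbon, which is a step that the two limits leave unreadable from compound 1 to compound 2 and offers no size to carry over. No step beyond the usual scatter in this assay is therefore expected, and no direction can be foreseen. The expected step is a step that the limit leaves unreadable from compound 2 to compound 3 on this estimate. For compound 3 the estimated value is 4000 nM with an expected range from 1200 nM to 15000 nM and a good chance of only a limit.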

Compound 3, half-maximal inhibitory concentration: > 4000 nM
Compound 3: a limit, no number; the forecaster's own chance of this, stated with the estimate: 60%; the middle value sits exactly at the limit.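

Among these compounds, compound 1, compound 2 and compound 3 all stand only as limits, and no step among them can be read. The compounds shown leave open where any of them truly lies in this assay, and whether 3-ethynylphenyl or 4-chlorophenyl on the amine nitrogen makes any difference there.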